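This account rests on a few compounds, and the source may have more. Where it says the series, first, only, none or still open, it means among the compounds named here.

Two compounds share one core and differ only in the aromatic group on an amine nitrogen in a ring. Compound 1 `O=C1c2ccccc2S(=O)(=O)N1CCCCCCN1CCN(c2ccccc2Cl)CC1` carries a 2-chlorophenyl there, compound 2 `O=C1c2ccccc2S(=O)(=O)N1CCCCCCN1CCN(c2ccc(Cl)c(Cl)c2)CC1` a 3,4-dichlorophenyl. In an ADME assay on HEK293 cells for displacement of a labelled ligand from 5-hydroxytryptamine receptor 7 (Homo sapiens), read by radioligand binding, with a stated time of 1 h (on this read-out higher numbers stand for weaker inhibition and lower numbers for stronger inhibition), compound 1 gives 120 nM and compound 2 gives 258 nM. Compound 1 thus holds the lowest number of the two, and the step of a 2.2-fold higher number from compound 1 to compound 2 (0.33 log units; beyond the scatter) shows that swapping one chlorinated ring for another already shifts the read-out. Compound 3 `O=C1c2ccccc2S(=O)(=O)N1CCCCCCN1CCN(c2ncccn2)CC1` has not yet been measured. Its change from compound 1 is pyrimidin-2-yl in place of 2-chlorophenyl on an amine nitrogen in a ring. For the measured compounds named here, only one measured step bears on this, and loosely: the step from compound 1 to compound 2 also exchanged the group on the same ring nitrogen and gave a modest rise. In compound 3 an aromatic ring with 2 hetero atoms replaces one of carbon only, a larger change in kind, so a somewhat larger step toward a higher number is expected, a 2.9-fold higher number from compound 1 to compound 3 (0.46 log units; beyond the scatter). Compound 3 is therefore estimated to give about 350 nM in this assay, with a likely range from 110 nM to 1100 nM.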

Compound 3, inhibition constant: 35 nM
Estimate against measurement, compound 3: 10-fold (1.00 log units) above; measured number below the stated range.
By their numbers in this assay, from the lowest: compound 3; then compound 1; then compound 2.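

The change to pyrimidin-2-yl shows that this position on the ring nitrogen does not need a chlorinated carbon-only ring: in this assay, an aromatic ring with 2 hetero atoms gives a 3.4-fold lower number from compound 1 to compound 3 (0.54 log units; beyond the scatter), whereas the earlier exchange of one chlorinated ring for another gave a 2.2-fold higher number from compound 1 to compound 2 (0.33 log units; beyond the scatter). The exchange at this same position can therefore move the number in either direction, and the spread among the three groups reaches a 7.4-fold lower number from compound 2 to compound 3 (0.87 log units; beyond the scatter), leaving compound 3 with the strongest inhibition of the set. Nothing measured here explains why the pyrimidin-2-yl group does better than either chlorinated ring.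

The change from compound 1 to compound 3 removes the chlorine and brings ring nitrogen atoms in at the same time, so these compounds cannot show which of the two matters; an unsubstituted phenyl and a pyridin-2-yl ring at this position would help to separate them. From the compounds shown here alone, it also remains open whether the order of the three groups would hold with a shorter chain between the shared core and the six-membered ring.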